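Swapping the triazole substituent in a furanone series

The source may hold more compounds than are shown below. What is called first, only, known or untested is meant among the compounds shown, and "the series" means these compounds.

Measured so far:
- compound 1 `O=C1O/C(=C\Cn2cc(-c3cc(F)cc(F)c3)nn2)C(OCc2ccccc2)=C1OCc1ccccc1`: 17700 nM
- compound 2 `CCCCc1cn(C[C@H](O)[C@H]2OC(=O)C(OCc3ccccc3)=C2OCc2ccccc2)nn1`: 18100 nM
- compound 3 `O=C1O[C@H]([C@@H](O)Cn2cc(C3CC3)nn2)C(OCc2ccccc2)=C1OCc1ccccc1`: 26500 nM

Of the compounds shown here, three share a core and have been tested in a functional assay on HeLa cells (Homo sapiens) for antiproliferative activity, read by MTT assay, with a stated time of 72 h; a lower number here means a stronger inhibitor, a higher number a weaker inhibitor. Compound 1, carrying a difluorophenyl group on the triazole, gives 17700 nM. Compound 2, with a butyl group there, gives 18100 nM, and compound 3, with a cyclopropyl group, gives 26500 nM. Compound 3 has the highest number of the three, yet its gap to each of the others lies within the scatter, so the three cannot be ordered on these data.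

Compound 4 `COc1ccc(-c2cn(C[C@H](O)[C@H]3OC(=O)C(OCc4ccccc4)=C3OCc3ccccc3)nn2)cc1` differs from compound 3 in one place: 4-methoxyphenyl in place of cyclopropyl on an aromatic carbon. Among the measured compounds shown here, the only single-change step available, a 1.5-fold higher number from compound 2 to compound 3 (0.17 log units; within the scatter), shows that exchanging one small carbon group for another at this position did not move the number beyond the scatter, and compound 1, with an aromatic ring on the same triazole carbon, sits in the same range. No step beyond the scatter is therefore expected for a 1.3-fold lower number from compound 3 to compound 4 (0.12 log units; within the scatter), and compound 4 is estimated at 20000 nM, with a range from 8000 nM to 50000 nM.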

Compound 4, half-maximal inhibitory concentration: 16400 nM
Compound 4: the middle estimate sits 1.2-fold (0.09 log units) above what was measured; measured number inside the range.
By their numbers in this assay, from the lowest: compounds 4, 1, 2 and 3 (each within the scatter of the next).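

Putting 4-methoxyphenyl, with its six-membered aromatic ring and one hydrogen-bond acceptor, in place of cyclopropyl gives a 1.6-fold lower number from compound 3 to compound 4 (0.21 log units; within the scatter) in this assay, and putting it in place of butyl gives a 1.1-fold lower number from compound 2 to compound 4 (0.04 log units; within the scatter). This aromatic carbon therefore accepts a substituted aromatic ring of 8 heavy atoms with no change beyond the scatter, which the earlier single-change step, between two groups without an aromatic ring, could not show. No measurement at hand offers a reason for this flat result.

As far as these compounds go, whether any group on this carbon can move the number beyond the scatter remains open. An amine, a carboxylic acid or a longer chain ending in a hydroxyl group would test this, as would a phenyl ring carrying no methoxy group.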